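Changing the Aryl Group on the Amide Nitrogen

The source may report more compounds than this note shows. Statements on the series, on what has been measured and on what is new or still open speak of the compounds shown alone.

In a functional assay on A549 cells (Homo sapiens) for cytotoxicity, read by MTT assay, with a stated time of 72 h (on this read-out higher numbers stand for weaker inhibition and lower numbers for stronger inhibition), compound 1 `O=C(CN1CCN(c2nnc(Cc3ccncc3)c3ccccc23)CC1)Nc1cccc(Br)c1` gives 1530 nM, while compound 2 `Cc1ccc(F)cc1NC(=O)CN1CCN(c2nnc(Cc3ccncc3)c3ccccc23)CC1` gives 38900 nM, the higher of the two numbers and so the weaker inhibition. Compound 3 `O=C(CN1CCN(c2nnc(Cc3ccncc3)c3ccccc23)CC1)Nc1ccc(F)c(Cl)c1` alters one group: 3-chloro-4-fluorophenyl in place of 5-fluoro-2-methylphenyl on an amide-type nitrogen. Among the compounds with values here, the only measured step bearing on this, a 25-fold higher number from compound 1 to compound 2 (1.41 log units; beyond the scatter), was large and brought in the same 5-fluoro-2-methylphenyl that now leaves. Like the 3-bromophenyl of compound 1, the entering 3-chloro-4-fluorophenyl has no methyl. A large downward change is therefore expected in this assay, estimated as a 13-fold lower number from compound 2 to compound 3 (1.11 log units; beyond the scatter). The value expected for compound 3 is 3000 nM, with an estimated range of 800 nM to 15000 nM.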

Compound 3, half-maximal inhibitory concentration: 12300 nM
For compound 3 the middle estimate is 4.1-fold (0.61 log units) below the measured one; measured number inside the range.
By their numbers in this assay, from the lowest: compound 1; then compound 3; then compound 2.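

Putting 3-chloro-4-fluorophenyl in place of 5-fluoro-2-methylphenyl gives a 3.2-fold lower number from compound 2 to compound 3 (0.50 log units; beyond the scatter) but, set against the 3-bromophenyl group, the same change leaves an 8.0-fold higher number from compound 1 to compound 3 (0.91 log units; beyond the scatter) on this amide-type nitrogen. Losing the methyl therefore does not by itself bring the number back to that of compound 1, and the two aryl groups without a methyl still differ clearly. No measurement at hand explains these differences.

Going by these compounds, whether a 3-chlorophenyl or an unsubstituted phenyl would fall nearer compound 1 or compound 3 stays open. So does whether a cyclohexyl could stand in for the aryl ring here.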